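The source may hold more compounds than are shown below. What is called first, only, known or untested is meant among the compounds shown, and "the series" means these compounds.

Compound 1 `C/C(=N\Nc1nc(-c2ccc(F)cc2)cs1)c1sc(C)nc1C`, compound 2 `C/C(=N\Nc1nc(-c2ccc(Cl)cc2)cs1)c1sc(C)nc1C` and compound 3 `C/C(=N\Nc1nc(-c2ccc(F)cc2)cs1)c1sc(-c2ccccc2)nc1C` were tested in a toxicity assay on MCF7 cells (Homo sapiens) for cytotoxicity, read by MTT assay; on this read-out lower numbers stand for stronger inhibition of growth and higher numbers for weaker inhibition of growth. For compound 1 the result is only a limit of the assay, > 100 ug/mL. For compound 2 the result is likewise a limit, > 100 ug/mL. For compound 3 too the result is a limit, > 100 ug/mL. The change from compound 1 to compound 2 is chloro in place of fluoro on an aromatic carbon, and in this assay it gave a step that the two limits leave unreadable from compound 1 to compound 2, because of the limit of > 100 ug/mL in this assay, at which 3 of the 3 values shown sit. The core of compound 3 differs from the core of compound 1 by phenyl in place of methyl on an aromatic carbon, with a step that the two limits leave unreadable from compound 1 to compound 3. Compound 4 `C/C(=N\Nc1nc(-c2ccc(Cl)cc2)cs1)c1sc(-c2ccccc2)nc1C` is not yet measured; it stands to compound 3 as compound 2 stands to compound 1, through (chloro in place of fluoro on an aromatic carbon), the same change at the same place. Because compound 1 and compound 2 both sat at the limit of > 100 ug/mL in this assay, at which 3 of the 3 values shown sit, the expected step is a step that the limit leaves unreadable from compound 3 to compound 4, small in either direction. Compound 4 is therefore estimated at 150 ug/mL, between 60 ug/mL and 400 ug/mL, and very likely again only a limit.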

Compound 4, concentration for 50% growth inhibition: > 100 ug/mL
Compound 4 was reported as a limit (the forecaster's own chance of this, stated with the estimate: 85%); the middle value does not contradict the limit.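

Compound 4 gives only a limit, as do compound 2 and compound 3, so neither step to compound 4 can be read: the limit of > 100 ug/mL in this assay, at which 4 of the 4 values shown sit.

The compounds shown leave open whether chloro or fluoro, or phenyl or methyl, makes any difference in this assay.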